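The source may report more compounds than this note shows. Statements on the series, on what has been measured and on what is new or still open speak of the compounds shown alone.

Of the compounds shown here, two have been measured so far in a functional assay on RXF 393 cells (Homo sapiens) for cytotoxicity, read by sulforhodamine B assay, with a stated time of 48 h (on this read-out lower numbers stand for stronger inhibition of growth and higher numbers for weaker inhibition of growth), and compound 1 (`COc1cc(C(=O)c2ccc(OC)c(O)c2OC)cc(OC)c1O`) stands lowest of them at 755 nM in that test, while compound 2 (`COc1cc(C(=O)c2ccc3c(c2)oc(=O)n3S(C)(=O)=O)cc(OC)c1OC`) gives 4630 nM and so lies beyond the scatter above it. Compound 3 (`COc1ccc(C(=O)c2cc(OC)c(OC)c(OC)c2)c(OC)c1O`) departs from compound 1 by a single change (methyl in place of hydrogen on an oxygen on an aromatic ring) of hydroxy to methoxy, with methyl in place of hydrogen on an oxygen on an aromatic ring. For the measured compounds named here, no measured pair shows what such a change does here, so any forecast is a judgement with a wide range. A step towards stronger inhibition of growth, beyond the scatter, is expected. The estimate means an expected step (a 7.6-fold lower number from compound 1 to compound 3 (0.88 log units; beyond the scatter)) to a lower number. Compound 3 is expected to give about 100 nM within a range from 15 nM to 600 nM when tested.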

Compound 3, concentration for 50% growth inhibition: 15.9 nM
Compound 3: middle estimate off by 6.3-fold (0.80 log units), on the high side, within the range that was stated.
By their numbers in this assay, from the lowest: compound 3; then compound 1; then compound 2.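

In this assay the change from hydroxy to methoxy at this oxygen on an aromatic ring gives a 47-fold lower number from compound 1 to compound 3 (1.68 log units; beyond the scatter) and so shows that this position responds strongly to a single added methyl. The step runs towards stronger inhibition of growth, which means that the hydrogen on this oxygen is not needed for activity in this test, at least on the core of compound 1. Nothing available here accounts for the size of this step.

The compounds shown leave open whether the gain is specific to methyl or would persist with an ethyl ether or a longer chain on this oxygen. They also leave open how an amine in place of the hydroxy would behave here, and what the hydroxy that remains in compound 3 contributes.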